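A few compounds are considered here, and "the series" means these few. Any claim that something is new, unique, unknown or untested is made for them only; others in the source may bear on it.

Measured so far in a functional assay on K562 cells (Homo sapiens) for antiproliferative activity, read by MTT assay, with a stated time of 48 h; on this read-out higher numbers stand for weaker inhibition and lower numbers for stronger inhibition:
Compound 1 `CCCCc1ccc2c(c1)C(=O)C(=O)N2`: > 10000 nM, a limit.
Compound 2 `O=C1Nc2ccc(-c3ccc(C(F)(F)F)cc3)cc2C1=O`: > 10000 nM, a limit.
Compound 3 `COc1ccc(-c2ccc3c(c2)C(=O)C(=O)N3c2ccc(OC)cc2)cc1`: > 10000 nM, a limit.

Compound 3 has no number of its own, and its > 10000 nM is only a limit. Within the data shown here, the series so far stands at the limit of > 10000 nM in this assay, at which 3 of the 3 values shown sit, so no order among the three compounds can be read.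

Compound 4 `COc1ccc(-c2ccc3c(c2)C(=O)C(=O)N3Cc2ccc(Br)cc2)cc1` differs from compound 3 in one place, with 4-bromobenzyl in place of 4-methoxyphenyl on an amide-type nitrogen in a ring.

Among the measured compounds shown here, no measured step between compounds differing in one place bears on this change, so the expectation is a judgement with wide uncertainty. A step toward stronger inhibition in this assay, beyond the usual scatter, is expected, although a result that stays at the limit remains possible. The expected step of an at least 20-fold lower number from compound 3 to compound 4 (1.30 log units; beyond the scatter) starts from a limit, so its size is only an estimate. For compound 4 the estimated value is 500 nM, with an expected range of 50 nM to 8000 nM.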

Compound 4, half-maximal inhibitory concentration: 100 nM
For compound 4 the middle estimate is 5.0-fold (0.70 log units) above the measured one, within the range that was stated.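

In this assay, the group on the amide-type nitrogen in a ring proves able to move the read-out: 4-bromobenzyl in place of 4-methoxyphenyl gives an at least 100-fold lower number from compound 3 to compound 4 (2.00 log units; beyond the scatter). Compound 3 stands at > 10000 nM, which is a limit and not a number. Compound 4 is the only compound shown with a measured number rather than a limit: the limit of > 10000 nM in this assay, at which 3 of the 4 values shown sit.

The change replaces the bromine-bearing benzyl for a methoxy-bearing phenyl in one move, so the compounds shown do not separate the contribution of the halogen from that of the benzyl link, and 4-bromophenyl and 4-methoxybenzyl on this nitrogen are the open comparisons. Also open, as far as these compounds go, is whether a longer chain ending in an amine or a carboxylic acid at this nitrogen would keep the activity.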